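Acid Swap: Tetrazolylphenyl Replaces Carboxypyridinyl

The compounds below may be only part of what the source reports. "The series", "measured", "known", "first", "only" and "open" are said of these compounds alone.

Compound 1 `CN1CCC[C@H](OCc2cc(Cl)cc(Cl)c2)[C@@H]1c1ccccc1` and compound 2 `O=C(O)c1ccc(CN2CCC[C@H](OCc3cc(Cl)cc(Cl)c3)[C@@H]2c2ccccc2)cn1` share one core. In an assay on isolated protein for activation of cGMP-dependent protein kinase 1 (Homo sapiens), read by ADP-Glo, with stated times of 120 min and 40 min (on this read-out higher numbers stand for an effect only at larger amounts of compound and lower numbers for an effect already at smaller amounts), compound 1 gives only a limit, > 200000 nM. In this assay compound 2 likewise gives only a limit, > 200000 nM. Within the data shown here, the only measured step, a step that the two limits leave unreadable from compound 1 to compound 2, therefore has no readable size, and the limit of > 200000 nM in this assay, at which 2 of the 2 values shown sit, is all the numbers show. Compound 3 `Clc1cc(Cl)cc(CO[C@H]2CCCN(Cc3ccc(-c4nn[nH]n4)cc3)[C@H]2c2ccccc2)c1` differs from compound 2 by 4-(2H-tetrazol-5-yl)phenyl in place of 6-carboxypyridin-3-yl on a saturated chain carbon bound to an amine nitrogen in a ring. No readable step bears on this change, so no direction beyond the scatter is expected in this assay. Compound 3 is expected at 200000 nM, between 100000 nM and 400000 nM, most likely again only a limit. The expected step of a number no higher from compound 2 to compound 3 (the limit leaves the size open) is near none.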

Compound 3, half-maximal effective concentration: 74000 nM
The estimate for compound 3 lay 2.7-fold (0.43 log units) above the measured number; the measured number lies below the stated range.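

On a saturated chain carbon bound to an amine nitrogen in a ring, 4-(2H-tetrazol-5-yl)phenyl gives an at least 2.7-fold lower number from compound 2 to compound 3 (0.43 log units; beyond the scatter) in this assay, and, in place of hydrogen, an at least 2.7-fold lower number from compound 1 to compound 3 (0.43 log units; beyond the scatter). Among these compounds, the step from compound 1 to compound 2 cannot be read, so these are the first signs that a change at this place can shift the number. Only compound 3 gives a number rather than a limit: the limit of > 200000 nM in this assay, at which 2 of the 3 values shown sit.

On these data alone, the true size of both steps stays open. Also open, as far as these compounds go, is whether the 2H-tetrazol-5-yl group is needed, or whether a plain phenyl or a sulfonamide on that ring would give the same shift.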